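A Methylphenyl Group Replaces Dichlorophenyl on a Shared Core

This account rests on a few compounds, and the source may have more. Where it says the series, first, only, none or still open, it means among the compounds named here.

Of the compounds shown here, three built on one shared core have been measured in a functional assay on CCRF-CEM cells (Homo sapiens) for cytotoxicity, read by propidium iodide staining, with a stated time of 48 h; a higher number here means that more compound is tolerated, a lower number that less compound is tolerated. Compound 1 `O=C(CN1C(=O)S/C(=C/c2ccco2)C1=O)Nc1ccc(Cl)c(Cl)c1` gives 7800 nM, the second highest of the three numbers. Compound 3 `O=C(CN1C(=O)S/C(=C/c2ccco2)C1=O)Nc1nc2ccccc2s1` gives a lower number, 1700 nM, and compound 2 `O=C(CN1C(=O)S/C(=C/c2ccco2)C1=O)Nc1ccc(Cl)cc1C(F)(F)F` gives a higher one, 79900 nM. Both gaps to compound 1 lie beyond the scatter, so compound 1 sits in the middle of a wide spread.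

Compound 4 `Cc1ccc(NC(=O)CN2C(=O)S/C(=C/c3ccco3)C2=O)cc1` has not yet been measured. Its difference from compound 1 is 4-methylphenyl in place of 3,4-dichlorophenyl on an amide-type nitrogen. Among the compounds with values here, no measured pair isolates this exchange, so the expectation rests on thin evidence. Within the data shown here, the one other phenyl-bearing comparison is compound 2 at 79900 nM, which stands well above compound 1 and suggests that a changed phenyl group is more likely to raise the number than to lower it. That single case cannot fix the size of the step. In this assay, a moderate upward step, only modestly beyond the scatter, is expected, estimated as a 2.3-fold higher number from compound 1 to compound 4 (0.36 log units; beyond the scatter). For compound 4 the estimated value is 18000 nM, with an expected range from 5000 nM to 65000 nM.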

Compound 4, half-maximal cytotoxic concentration: 102000 nM
The estimate for compound 4 lay 5.7-fold (0.75 log units) below the measured number, and the stated range ends below it.
By their numbers in this assay, from the lowest: compound 3; then compound 1; then compounds 2 and 4 (each within the scatter of the next).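

In this assay, 4-methylphenyl in place of 3,4-dichlorophenyl on the amide-type nitrogen gives a 13-fold higher number from compound 1 to compound 4 (1.12 log units; beyond the scatter), a large step and the first at this position that can be read as a single exchange. The aromatic ring of carbon stays, and hydrogen-bond donors, hydrogen-bond acceptors and net charge are the same on both sides, so the number at this position depends strongly on what the phenyl ring carries and not only on a phenyl ring being there. Nothing shown here accounts for the size of this step.

The exchange removes chlorine and brings in methyl at once, so the compounds shown leave open whether the step follows the loss of chlorine, the arrival of methyl, or both together. On these data alone, it also remains open where the number would fall with a plain phenyl group on this nitrogen, or with a phenyl ring carrying a methoxy group or an amine.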